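The compounds below may be only part of what the source reports. "The series", "measured", "known", "first", "only" and "open" are said of these compounds alone.

Measured in a physicochemical assay for solubility, read by HPLC, in phosphate buffer, with a stated time of 24 h, at pH 7.4, tested at 100 uM; a lower number here means a less soluble compound, a higher number a more soluble compound:
Compound 1 `O=C(CCCCCNc1c(Nc2ccccc2)c(=O)c1=O)NO`: 47000000 nM
Compound 2 `O=C(CCCCCNc1c(NCc2ccccc2)c(=O)c1=O)NO`: 75000000 nM
Compound 3 `C[C@H](Nc1c(NCCCCCC(=O)NO)c(=O)c1=O)c1ccccc1`: 73000000 nM

Compound 3 cannot be told apart from the other two compounds, as a 1.6-fold higher number from compound 1 to compound 3 (0.19 log units; within the scatter) and a 1.0-fold lower number from compound 2 to compound 3 (0.01 log units; within the scatter) both show. Compound 4 `Cc1ccc([C@H](C)Nc2c(NCCCCCC(=O)NO)c(=O)c2=O)cc1` is compound 3 with one change: methyl in place of hydrogen on an aromatic carbon. Among the compounds with values here, no measured step makes exactly this change. The closest one also adds a methyl, but on a saturated chain carbon, and that is the step already given from compound 2, which stayed within the scatter. The swap of phenyl for benzyl, a 1.6-fold higher number from compound 1 to compound 2 (0.20 log units; within the scatter), stayed within it as well. The expected step is therefore small, a 1.2-fold lower number from compound 3 to compound 4 (0.09 log units; within the scatter), and no larger than the scatter. The estimate for compound 4 is 60000000 nM, with an expected range of 32000000 nM to 95000000 nM.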

Compound 4, solubility: 76000000 nM
For compound 4 the middle estimate is 1.3-fold (0.10 log units) below the measured one; measured number inside the range.
By their numbers in this assay, from the lowest: compounds 1, 3, 2 and 4 (each within the scatter of the next).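

Changing phenyl to 4-methylphenyl gives a 1.0-fold higher number from compound 3 to compound 4 (0.02 log units; within the scatter) in this assay and so stays within the scatter. Compound 1, compound 2 and compound 3 differ only in what joins the ring to the nitrogen, whereas this change is on the aromatic ring itself, para to a large group, and a methyl there leaves the solubility reading indistinguishable from that of compound 3. Going by these compounds, whether an amine or a carboxylic acid at this position would also stay within the scatter remains open. Nothing available explains why this methyl leaves the reading within the scatter.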